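The compounds below may be only part of what the source reports. "The series", "measured", "known", "first", "only" and "open" are said of these compounds alone.

Compound 1 `O=C1Nc2cc(Br)ccc2/C1=N/NC(=S)N1CCN(c2ccccc2)CC1` gives 15800 nM in a functional assay on A549 cells (Homo sapiens) for inhibition, read by MTT assay, with a stated time of 72 h; a lower number here means a stronger inhibitor, a higher number a weaker inhibitor.
Compound 2 `Cc1ccccc1N1CCN(C(=S)N/N=C2\C(=O)Nc3ccc(Cl)cc32)CC1` gives 6520 nM in this assay.
Compound 3 `O=C1Nc2ccc(Cl)cc2/C1=N/NC(=S)N1CCN(c2ccc(Cl)cc2)CC1` gives 8180 nM in this assay.

Among these three numbers compound 3 stands second highest, yet its gaps to both others lie within the usual scatter, so no order among the three can be claimed. Compound 4 `O=C1Nc2ccc(Cl)cc2/C1=N/NC(=S)N1CCN(c2ccc([N+](=O)[O-])cc2)CC1` differs from compound 3 in one place: nitro in place of chloro on an aromatic carbon. Going by the values given here, the one measured step that bears on this is the exchange of the aryl group on the same ring nitrogen, a 1.3-fold higher number from compound 2 to compound 3 (0.10 log units; within the scatter), which stayed within the scatter. A change of a single substituent on that phenyl ring is therefore expected to shift the number by no more than the scatter, in no set direction: a 1.0-fold lower number from compound 3 to compound 4 (0.01 log units; within the scatter). For compound 4 the estimate in this assay is 8000 nM, with a range from 3000 nM to 22000 nM.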

Compound 4, half-maximal inhibitory concentration: 11800 nM
For compound 4 the middle estimate is 1.5-fold (0.17 log units) below the measured one, and the stated range covers the measured number.
By their numbers in this assay, from the lowest: compounds 2, 3, 4 and 1 (each within the scatter of the next, the first and the last beyond it).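

Swapping chloro for nitro on the phenyl ring, para to a large group, gives a 1.4-fold higher number from compound 3 to compound 4 (0.16 log units; within the scatter) in this assay. Replacing the 2-methylphenyl group with 4-nitrophenyl gives a 1.8-fold higher number from compound 2 to compound 4 (0.26 log units; within the scatter) and so also leaves the number within the scatter, which means that neither a larger group with hydrogen-bond acceptors at this place nor a change of both substituent and place separates these compounds. No measurement is at hand that would explain this result.

On these data alone, whether an amine or a carboxylic acid at this place would move the number beyond the scatter stays open. So does the effect of a longer chain there.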